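The source may report more compounds than this note shows. Statements on the series, on what has been measured and on what is new or still open speak of the compounds shown alone.

Series notes. Compound 1 `CN/C(=N/C#N)NCCCCc1nc(N)n[nH]1` and compound 3 `CN/C(=N/C#N)NCCCNc1nc(N)n[nH]1` share the cyanoguanidine end but differ in the core; how the two cores differ is not broken down here. Compound 2 `N#C/N=C(\NCCCCc1nc(N)n[nH]1)NCCSc1ccccc1` is made from compound 1 by the change ((phenylsulfanyl)methyl in place of hydrogen on a saturated chain carbon bound to an amine nitrogen). Compound 4 `N#C/N=C(\NCCCNc1nc(N)n[nH]1)NCCSc1ccccc1` is made from compound 3 by the same change, ((phenylsulfanyl)methyl in place of hydrogen on a saturated chain carbon bound to an amine nitrogen), at the same place.

In a functional assay on Sf9 cells for antagonist activity at histamine H2 receptor (Homo sapiens), read by scintillation counting and GTPgammaS binding, with a stated time of 90 min (a higher number here means a more potent compound, by a factor of ten per unit of this negative logarithm, a lower number a less potent compound), compound 1 gives < 5, which is a limit of the assay and not a number. In this assay compound 2 gives < 5, again a limit of the assay. In this assay compound 3 gives < 5, also a limit of the assay. The step that the two limits leave unreadable from compound 1 to compound 2 therefore cannot be read, because of the limit of < 5 in this assay, at which 3 of the 3 values shown sit.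

Among the measured compounds shown here, for compound 4 the same change on the core of compound 3 is expected to give a step that the limit leaves unreadable from compound 3 to compound 4, a size that rests only on the fact that every value so far sits at the limit. The estimate for compound 4 in this assay is 4.7, and the most likely outcome is that the assay again reports only a limit.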

Compound 4, negative logarithm of the antagonist equilibrium constant: < 5
Compound 4: a limit, no number; the forecaster's own chance of this, stated with the estimate: 75%; the middle value lies beyond the limit too.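

In this assay compound 4 gives < 5 as a limit of the assay and not a number. Among the compounds shown here, no step from compound 3 or compound 2 to compound 4 can be read, because: (the limit of < 5 in this assay, at which 4 of the 4 values shown sit). The compounds shown leave open how far each lies from that limit, and whether either the (phenylsulfanyl)methyl change or the difference in core alters potency at all.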